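This account rests on a few compounds, and the source may have more. Where it says the series, first, only, none or still open, it means among the compounds named here.

In a functional assay on K562/A02 cells (Homo sapiens) for antiproliferative activity, read by MTT assay (on this read-out lower numbers stand for stronger inhibition and higher numbers for weaker inhibition), compound 1 (`C/C(=N\NC(=S)NCCCCCC(=O)NO)c1ccc(Br)cc1`) gives 440 nM and compound 2 (`COc1cccc(/C(C)=N/NC(=S)NCCCCCC(=O)NO)c1`) gives 1890 nM while compound 3 (`C/C(=N\NC(=S)NCCCCCC(=O)NO)c1ccc(F)cc1`) gives 1020 nM on the same read-out. Compound 3 belongs with compound 2, well away from compound 1: a 1.9-fold lower number from compound 2 to compound 3 (0.27 log units; within the scatter) stays within the scatter, whereas a 2.3-fold higher number from compound 1 to compound 3 (0.37 log units; beyond the scatter) goes beyond it. The next structure, compound 4 (`C/C(=N\NC(=S)NCCCCCC(=O)NO)c1cccc(Br)c1`), puts 3-bromophenyl in place of 4-fluorophenyl on a carbon with a double bond to nitrogen, a change counted as 3-bromophenyl in place of 4-fluorophenyl on a carbon with a double bond to nitrogen in full.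

The most relevant evidence is a 2.3-fold higher number from compound 1 to compound 3 (0.37 log units; beyond the scatter) as a modest step, which, read backwards, links bromo with the lower number. For the measured compounds named here, that reading carries over only in part, since no measured compound has 3-bromophenyl itself. The modest 4.3-fold higher number from compound 1 to compound 2 (0.63 log units; beyond the scatter) alters both the group and its place, so the data cannot separate those two changes. Only part of the bromo gain is therefore expected to survive in compound 4. The expected change is a 1.5-fold lower number from compound 3 to compound 4 (0.16 log units; within the scatter) and would stay within the scatter. Compound 4 is estimated at 700 nM with 300 nM to 1600 nM as its expected range.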

Compound 4, half-maximal inhibitory concentration: 520 nM
The estimate for compound 4 lay 1.3-fold (0.13 log units) above the measured number; the measured number falls inside the stated range.
By their numbers in this assay, from the lowest: compounds 1, 4, 3 and 2 (each within the scatter of the next, the first and the last beyond it).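

In this assay, moving the bromine from 4-bromophenyl to 3-bromophenyl gives a 1.2-fold higher number from compound 1 to compound 4 (0.07 log units; within the scatter) and so leaves no readable difference between the two placements on the carbon with a double bond to nitrogen. With the substituent's place now held constant, a 3.6-fold lower number from compound 2 to compound 4 (0.56 log units; beyond the scatter) shows that bromo in place of methoxy on an aromatic carbon accounts for a change beyond the scatter, which the earlier step between compound 1 and compound 2 could not separate from the change of place. The direct swap, a 2.0-fold lower number from compound 3 to compound 4 (0.29 log units; within the scatter) as the change from 4-fluorophenyl to 3-bromophenyl, stays within the scatter, so this step alone does not set compound 4 apart from compound 3 even though compound 4 differs from compound 2 by more than the scatter.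

The compounds shown leave open whether 3-chlorophenyl, 3-aminophenyl or 2-bromophenyl on the same carbon would match the two bromophenyl compounds, and whether a group larger than methyl on that carbon would keep their numbers. No measurement given here explains why the two bromophenyl compounds give the numbers they do.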